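Coumarin propargylamines: a fluorobenzyl swap in compound 4

This account rests on a few compounds, and the source may have more. Where it says the series, first, only, none or still open, it means among the compounds named here.

Measured compounds:
Compound 1, `C#CCN(CCCOc1ccc2ccc(=O)oc2c1)Cc1ccc(C)cc1`, 7380 nM
Compound 2, `C#CCN(CCCCOc1ccc2ccc(=O)oc2c1)Cc1ccc(C(C)C)cc1`, 3500 nM
Compound 3, `C#CCN(CCCOc1ccc2ccc(=O)oc2c1)Cc1ccc(C(C)C)cc1`, 7580 nM

In an assay on isolated protein for inhibition of Amine oxidase [flavin-containing] B (Homo sapiens), read by fluorescence and Amplex Red, with stated times of 15 min and 20 min (on this read-out lower numbers stand for stronger inhibition and higher numbers for weaker inhibition), compound 2 gives the lowest of the three numbers; the nearest to it is compound 1, and the furthest is compound 3, both of them beyond the scatter. Within the data shown here, the only step between measured compounds that differ in one place is a 1.0-fold higher number from compound 1 to compound 3 (0.01 log units; within the scatter), so exchanging isopropyl for methyl on the aromatic carbon left the read-out unchanged within the scatter.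

Compound 4, `C#CCN(CCCCOc1ccc2ccc(=O)oc2c1)Cc1cccc(F)c1`, has not yet been measured in this assay. It differs from compound 2 as follows: 3-fluorophenyl in place of 4-isopropylphenyl on a saturated chain carbon bound to an amine nitrogen. Among the measured compounds shown here, no measured step covers this exchange directly. For the measured compounds named here, the one step that touches the same aryl substituent, compound 1 to compound 3, was within the scatter, which suggests that the group on this ring is not what sets the number here, although the 3-fluorophenyl group sits differently from either of those two. A modest step, most likely in the weaker direction or none beyond the scatter, is therefore expected. Compound 4 is estimated at 4500 nM, with a range from 1800 nM to 11000 nM, corresponding to an expected step of a 1.3-fold higher number from compound 2 to compound 4 (0.11 log units; within the scatter).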

Compound 4, half-maximal inhibitory concentration: 1550 nM
Estimate against measurement, compound 4: 2.9-fold (0.46 log units) above; the measured number lies below the stated range.
By their numbers in this assay, from the lowest: compound 4; then compound 2; then compounds 1 and 3 (each within the scatter of the next).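

In this assay the exchange of 4-isopropylphenyl for 3-fluorophenyl on a saturated chain carbon bound to an amine nitrogen gives a 2.3-fold lower number from compound 2 to compound 4 (0.35 log units; beyond the scatter), so the aryl group at this place can move the number beyond the scatter. The earlier step, a 1.0-fold higher number from compound 1 to compound 3 (0.01 log units; within the scatter), had not shown this, as it stayed within the scatter and involved only a change from methyl to isopropyl on the ring of compounds with the shorter chain. The new step is a single exchange of whole groups, with 7 heavy atoms entering for 9, so it cannot separate the loss of the isopropyl group, the entry of fluorine and the change of place on the ring, and nothing measured on these compounds accounts for it.

On these data alone, what remains open is which of these parts carries the step; 4-fluorophenyl, 3-chlorophenyl or plain phenyl at the same place would begin to separate them. Also open, as far as these compounds go, is whether 3-fluorophenyl gives a similar step on the shorter chain of compound 3, and how a longer chain than that of compound 4 would read.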